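A Second Halogen Swap on the Sulfonamide Aryl Ring

The compounds below may be only part of what the source reports. "The series", "measured", "known", "first", "only" and "open" are said of these compounds alone.

Three compounds have been measured in an assay on isolated protein for binding affinity to 5-hydroxytryptamine receptor 6 (Homo sapiens); a higher number here means a weaker inhibitor, a lower number a stronger inhibitor:
compound 1, `COc1ccc(S(=O)(=O)Nc2cc(Br)cc(Br)c2)cc1N1CCNCC1`: 0.501 nM
compound 2, `COc1ccc(S(=O)(=O)Nc2ccc(C)cc2Br)cc1N1CCNCC1`: 7.94 nM
compound 3, `COc1ccc(S(=O)(=O)Nc2cc(Br)cc(Cl)c2Cl)cc1N1CCNCC1`: 3.98 nM

Compound 1 has the lowest number of the three; the nearest is compound 3, with a 7.9-fold higher number from compound 1 to compound 3 (0.90 log units; beyond the scatter), and the furthest is compound 2, with a 16-fold higher number from compound 1 to compound 2 (1.20 log units; beyond the scatter). Compound 4, `COc1ccc(S(=O)(=O)Nc2cc(Br)cc(F)c2Cl)cc1N1CCNCC1`, is not yet measured. It differs from compound 1 as follows: 5-bromo-2-chloro-3-fluorophenyl in place of 3,5-dibromophenyl on a sulfonamide nitrogen. The entering group matches that of compound 3 except for a fluorine in place of one chlorine, so the most relevant step is a 7.9-fold higher number from compound 1 to compound 3 (0.90 log units; beyond the scatter); between compound 2 and compound 3 the step of a 2.0-fold lower number from compound 2 to compound 3 (0.30 log units; within the scatter) is within the scatter. A modest rise in the number is therefore expected for compound 4, a 7.0-fold higher number from compound 1 to compound 4 (0.84 log units; beyond the scatter). Compound 4 is estimated at 3.5 nM, in the range 1.2 nM to 10 nM.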

Compound 4, inhibition constant: 3.16 nM
Compound 4: the middle estimate sits 1.1-fold (0.04 log units) above what was measured; the measured number falls inside the stated range.
By their numbers in this assay, from the lowest: compound 1; then compounds 4, 3 and 2 (each within the scatter of the next, the first and the last beyond it).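

In this assay fluoro in place of chloro on an aromatic carbon leaves the number within the scatter, at a 1.3-fold lower number from compound 3 to compound 4 (0.10 log units; within the scatter), so this halogen swap does not separate the two compounds. Moving away from 3,5-dibromophenyl again costs affinity, with a 6.3-fold higher number from compound 1 to compound 4 (0.80 log units; beyond the scatter), whereas a 2.5-fold lower number from compound 2 to compound 4 (0.40 log units; beyond the scatter) gives a step beyond the scatter relative to 2-bromo-4-methylphenyl. Nothing available explains these steps.

Still open, from the compounds shown here alone, is how a phenyl ring carrying a trifluoromethyl, a nitrile or an amine on the sulfonamide nitrogen would compare with 3,5-dibromophenyl.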